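The source may hold more compounds than are shown below. What is called first, only, known or untested is meant among the compounds shown, and "the series" means these compounds.

Measured in a functional assay on MM1.S cells (Homo sapiens) for inhibition, with a stated time of 72 h; a higher number here means a weaker inhibitor, a lower number a stronger inhibitor:
- Compound 1 `O=C(NO)c1ccc(CN(C2CC2)S(=O)(=O)c2cc(F)c(F)c(F)c2F)cc1`: 480 nM
- Compound 2 `CC(C)N(Cc1ccc(C(=O)NO)cc1)S(=O)(=O)c1c(F)c(F)c(F)c(F)c1F`: 440 nM
- Compound 3 `CC(C)N(Cc1ccc(C(=O)NO)cc1)Cc1cc(F)c(F)c(F)c1F`: 11400 nM

Compound 1 and compound 2 lie within the scatter of each other, while compound 3 gives a far higher number than either, beyond the scatter. Compound 4 `COCCN(Cc1ccc(C(=O)NO)cc1)S(=O)(=O)c1cc(F)c(F)c(F)c1F` has not yet been measured. It carries 2-methoxyethyl in place of cyclopropyl on a sulfonamide nitrogen. Among the measured compounds shown here, no step between measured compounds shows what a change at this place does, so the expectation starts from compound 1 at 480 nM. A small step toward a higher number, within the scatter, is expected: a 1.1-fold higher number from compound 1 to compound 4 (0.06 log units; within the scatter). Compound 4 is estimated at 550 nM, with an expected range of 220 nM to 1400 nM.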

Compound 4, half-maximal inhibitory concentration: 710 nM
For compound 4 the middle estimate is 1.3-fold (0.11 log units) below the measured one, within the range that was stated.
By their numbers in this assay, from the lowest: compounds 2, 1 and 4 (each within the scatter of the next); then compound 3.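

In this assay, among the compounds shown here, the first readable step at this sulfonamide nitrogen is a 1.5-fold higher number from compound 1 to compound 4 (0.17 log units; within the scatter) on swapping cyclopropyl for 2-methoxyethyl. On this core, then, an open chain carrying a hydrogen-bond acceptor can replace the three-membered ring without a step beyond the scatter. Nothing available explains this result and no cause can be assigned. The compounds shown leave open whether a chain ending in an amine or a carboxylic acid, or a longer chain, would also stay within the scatter at this nitrogen.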